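The compounds below may be only part of what the source reports. "The series", "measured", "known", "first", "only" and "open" are said of these compounds alone.

Measured so far:
compound 1 `COc1ccc(-c2cnc3nc(N)nc(NC(C)C)c3n2)cc1OC`: 600 nM
compound 2 `COc1ccc(-c2cnc3nc(N)nc(N4CCN(C(=O)Nc5cccc(C)c5)CC4)c3n2)cc1OC`: 7 nM
compound 3 `CCOc1ccc(-c2cnc3nc(N)nc(OC(C)C)c3n2)cc1`: 10000 nM

Of the three compounds measured in a functional assay on cells (T-cell, Homo sapiens) for inhibition (a higher number here means a weaker inhibitor, a lower number a stronger inhibitor), compound 2 stands lowest. In this assay compound 2 gives 7 nM; compound 1 gives 600 nM, a higher number beyond the scatter, and compound 3 gives 10000 nM, the highest of the three and also beyond the scatter. All three share the same core; compound 2 carries the largest group on it.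

Compound 4 `COc1ccc(-c2cnc3nc(N)nc(N4CCN(c5ccccc5)CC4)c3n2)cc1OC` is not yet measured. It differs from compound 2 at one place: phenyl in place of (3-methylphenyl)carbamoyl on an amine nitrogen in a ring. Among the measured compounds shown here, no pair of measured compounds with a single change exists in this set, so there is no measured step to lean on. Because compound 2 gives 7 nM with the larger group, and the smaller group of compound 1 gives 600 nM, a move toward a higher number is expected for compound 4, though likely smaller than the gap between those two. The expected step is an 8.6-fold higher number from compound 2 to compound 4 (0.93 log units; beyond the scatter). Compound 4 is estimated at 60 nM, within 10 nM to 400 nM.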

Compound 4, half-maximal inhibitory concentration: 400 nM
Compound 4: the middle estimate sits 6.7-fold (0.82 log units) below what was measured; the range from low to high includes it.
By their numbers in this assay, from the lowest: compound 2; then compounds 4 and 1 (each within the scatter of the next); then compound 3.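

Among the compounds shown here, on the amine nitrogen in the six-membered non-aromatic ring with 2 nitrogen, the change to phenyl from (3-methylphenyl)carbamoyl gives in this assay a 57-fold higher number from compound 2 to compound 4 (1.76 log units; beyond the scatter) as the first single-place comparison. An aromatic ring of carbon on this ring is therefore not enough on its own to keep the low number of compound 2, and this position responds strongly to what links that ring to the nitrogen and what it carries. Nothing measured here accounts for the size of the step.

As far as these compounds go, the step removes the carbonyl, the amide hydrogen and the methyl together, so their separate contributions remain open. A phenylcarbamoyl without the methyl, an acetyl or a benzyl on the same nitrogen would separate these parts.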